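Fluorine on the Pendant Phenyl Ring of a Quinoline Amide

This account rests on a few compounds, and the source may have more. Where it says the series, first, only, none or still open, it means among the compounds named here.

Measured so far:
compound 1 `COc1cc2c(Oc3ccc(NC(=O)c4nn(-c5ccccc5)c(=O)c5ccccc45)cc3F)ccnc2cc1OCCCN1CCCC1` — 530 nM
compound 2 `COc1cc2c(Oc3ccc(NC(=O)c4nn(-c5cccc(F)c5)c(=O)c5ccccc45)cc3F)ccnc2cc1OCCCN1CCCC1` — 160 nM
compound 3 `COc1cc2c(Oc3ccc(NC(=O)c4nn(-c5ccccc5)c(=O)c5ccccc45)cc3F)ccnc2cc1OCCCN1CCC(C)CC1` — 580 nM

These three compounds share one core and were tested in a functional assay on MKN-45 cells (Homo sapiens) for cytotoxicity, read by MTT assay, with a stated time of 72 h; on this read-out higher numbers stand for weaker inhibition and lower numbers for stronger inhibition. The step of a 3.3-fold lower number from compound 1 to compound 2 (0.52 log units; beyond the scatter) came from fluoro in place of hydrogen on an aromatic carbon. The cores of compound 1 and compound 3 differ by 4-methylpiperidin-1-yl in place of pyrrolidin-1-yl on a saturated chain carbon, three bonds along the chain from an oxygen on an aromatic ring, a change that gave a 1.1-fold higher number from compound 1 to compound 3 (0.04 log units; within the scatter). Compound 4 `COc1cc2c(Oc3ccc(NC(=O)c4nn(-c5ccc(F)cc5)c(=O)c5ccccc45)cc3F)ccnc2cc1OCCCN1CCC(C)CC1` is not yet measured; it differs from compound 3 by fluoro in place of hydrogen on an aromatic carbon. This is the same kind of change as from compound 1 to compound 2, but not the same: there the fluoro sits meta to a large group, here para to a large group. Resting on the step of a 3.3-fold lower number from compound 1 to compound 2 (0.52 log units; beyond the scatter) and on compound 3 at 580 nM, a somewhat smaller gain is expected, as the step of a 1.9-fold lower number from compound 3 to compound 4 (0.29 log units; within the scatter) in this assay. Compound 4 is estimated at 300 nM, between 130 nM and 700 nM.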

Compound 4, half-maximal inhibitory concentration: 130 nM
Compound 4: the middle estimate sits 2.3-fold (0.36 log units) above what was measured; low and high end bracket the measured number.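

In this assay, fluoro in place of hydrogen on the phenyl ring gave a 4.5-fold lower number from compound 3 to compound 4 (0.65 log units; beyond the scatter), and this step matches the earlier one on the other core: the same change on two cores in this assay, a 3.3-fold lower number (0.52 log units; beyond the scatter) from compound 1 to compound 2 and a 4.5-fold lower number (0.65 log units; beyond the scatter) from compound 3 to compound 4, 1.3-fold (0.13 log units) apart, within the scatter of two such steps. Across these two cores, which carry pyrrolidin-1-yl or 4-methylpiperidin-1-yl on the chain, the gain from fluoro therefore carried over at about the same size. The two steps do not place the fluoro at the same position on the phenyl ring, however, so this pair cannot separate the effect of the core from that of the position, and two steps cannot establish a rule for the series.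

As far as these compounds go, it remains open whether a chloro or methoxy group on that phenyl ring would give a similar step. From the compounds shown here alone, it is also open whether the gain would hold with morpholine at the end of the chain.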